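The source may hold more compounds than are shown below. What is called first, only, known or untested is meant among the compounds shown, and "the series" means these compounds.

Measured compounds in an assay on CCRF-CEM cells for antagonist activity at C-C chemokine receptor type 4 (Homo sapiens), read by CellTiter-Glo, with stated times of 30 min and 60 min, in the presence of a further agent that is not named here; on this read-out lower numbers stand for stronger inhibition and higher numbers for weaker inhibition:
compound 1 `Cc1nn([C@H](C)c2ccc(Cl)cc2Cl)c2nc(N3CC[C@H](N4CCC[C@H]4C(N)=O)[C@H](C)C3)cnc12`: "not determined" (no result reported)
compound 2 `C[C@@H]1CC(c2cnc3c(C#N)nn([C@H](C)c4ccc(Cl)cc4Cl)c3n2)=CC[C@@H]1N1CCC[C@H]1C(N)=O`: 1380 nM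
compound 3 `C[C@@H]1CC(c2cnc3c(C#N)nn([C@H](C)c4ccc(Cl)cc4Cl)c3n2)=CC[C@@H]1N1CCC[C@H]1CO`: 70 nM

Compound 1 stands nowhere on the numbers: no result is reported for it in this assay. Compound 4 `Cc1nn([C@H](C)c2ccc(Cl)cc2Cl)c2nc(N3CC[C@H](N4CCC[C@H]4CO)[C@H](C)C3)cnc12` differs from it by hydroxymethyl in place of carbamoyl on a saturated ring carbon. Within the data shown here, the one measured step that bears on this change is a 20-fold lower number from compound 2 to compound 3 (1.29 log units; beyond the scatter), the same replacement on a different core, and it was large. As far as these compounds go, the step from compound 1 to compound 4 in this assay is therefore expected to be a lowering of similar size, though with no number for compound 1 the starting point stays open. Compound 3 is the nearest measured analogue of compound 4 and serves as the anchor. The value of compound 4 in this assay is estimated at 100 nM, within a range of 15 nM to 700 nM.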

Compound 4, half-maximal inhibitory concentration: 151 nM
Beside the measured number, compound 4's estimate is 1.5-fold (0.18 log units) below it, and the stated range covers the measured number.
By their numbers in this assay, from the lowest: compound 3; then compound 4; then compound 2.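

Compound 1 has no reported number in this assay, so the step from it to compound 4 cannot be read. The compounds shown leave open whether hydroxymethyl in place of carbamoyl lowers the number on this core. No supporting data bear on the result.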